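Replacing 4-nitrobenzyl with 3-bromobenzyl in compound 3

The source may hold more compounds than are shown below. What is called first, only, known or untested is meant among the compounds shown, and "the series" means these compounds.

Measured in a functional assay on HCT-116 cells (Homo sapiens) for antiproliferative activity, read by MTT assay, with a stated time of 24 h; a lower number here means a stronger inhibitor, a higher number a weaker inhibitor:
compound 1 `COc1cc(OC)c(-c2coc3cc(OCc4ccccc4F)ccc3c2=O)cc1OC` gives 2900 nM
compound 2 `COc1cc(OC)c(-c2coc3cc(OCc4ccc(F)cc4)ccc3c2=O)cc1OC` gives 950 nM
compound 3 `COc1cc(OC)c(-c2coc3cc(OCc4ccc([N+](=O)[O-])cc4)ccc3c2=O)cc1OC` gives > 10000 nM as a limit

Compound 3 has no number, only the limit of > 10000 nM in this assay, at which 1 of the 3 values shown sits, and so stands apart from compound 1 and compound 2. Compound 4 `COc1cc(OC)c(-c2coc3cc(OCc4cccc(Br)c4)ccc3c2=O)cc1OC` carries 3-bromophenyl in place of 4-nitrophenyl on a saturated chain carbon bound to an oxygen on an aromatic ring. The bearing steps are an at least 10-fold higher number from compound 2 to compound 3 (1.02 log units; beyond the scatter) and an at least 3.4-fold higher number from compound 1 to compound 3 (0.53 log units; beyond the scatter) both entering 4-nitrophenyl, while a 3.1-fold lower number from compound 1 to compound 2 (0.48 log units; beyond the scatter) shows the spread between the two fluorophenyl compounds. Leaving 4-nitrophenyl is therefore expected to give a modest to large step toward a lower number in this assay for compound 4. For compound 4 the estimate is 2500 nM with an expected range of 700 nM to 9000 nM in these notes. For compound 4 the expected step is an at least 4.0-fold lower number from compound 3 to compound 4 (0.60 log units; beyond the scatter) on this estimate.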

Compound 4, half-maximal inhibitory concentration: 1200 nM
The estimate for compound 4 lay 2.1-fold (0.32 log units) above the measured number; the measured number falls inside the stated range.
By their numbers in this assay, from the lowest: compounds 2 and 4 (each within the scatter of the next); then compound 1. At a limit, above all of these: compound 3.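

In this assay, 3-bromophenyl in place of 4-nitrophenyl gives an at least 8.3-fold lower number from compound 3 to compound 4 (0.92 log units; beyond the scatter), so among the compounds shown the weak end at this position belongs to 4-nitrophenyl alone. Against the fluorophenyl compounds, 3-bromophenyl gives a 1.3-fold higher number from compound 2 to compound 4 (0.10 log units; within the scatter) and a 2.4-fold lower number from compound 1 to compound 4 (0.38 log units; beyond the scatter), so a bromine on this ring is tolerated as well as the fluorine of 4-fluorophenyl. The step from compound 3 rests on a limit, not a number: the limit of > 10000 nM in this assay, at which 1 of the 4 values shown sits.

The compounds shown do not separate the identity of the ring substituent from its place on the ring. As far as these compounds go, how an amine or a carboxylic acid on this phenyl ring, or a longer chain to it, would read remains open.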